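A few compounds are considered here, and "the series" means these few. Any claim that something is new, unique, unknown or untested is made for them only; others in the source may bear on it.

Measured so far in a functional assay with Alpha-1A adrenergic receptor (Homo sapiens) as the target, read by calcium flux; a higher number here means a larger maximal response, a lower number a smaller maximal response:
compound 1 `CC(C)n1ncnc1-c1ccccc1NCC1=NCCN1`: 104%
compound 2 `c1ccc(-c2nc[nH]n2)c(NCC2=NCCN2)c1`: 135%

Compound 1 stands lowest of the two in this assay; compound 2 lies higher by a margin beyond the scatter. The two are not connected by a single change, so only their two values can be set side by side.

Compound 3 `CCCCn1ncnc1-c1ccccc1NCC1=NCCN1` differs from compound 1 as follows: butyl in place of isopropyl on an aromatic nitrogen. Within the data shown here, no measured pair shows this change. Butyl in place of isopropyl on an aromatic nitrogen is expected to move this assay little, if at all, with no step beyond the scatter in either direction. Compound 3 is therefore estimated at 105%, with a range of 85% to 130%. The expected step of a number 1 percentage points higher from compound 1 to compound 3 (within the scatter) is estimated to stay within the scatter.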

Compound 3, largest response reached (reported as maximal response), in percent of the reference or control that the assay uses: 86%
The estimate for compound 3 lay 19 percentage points above the measured number; the range from low to high includes it.
By their numbers in this assay, from the lowest: compound 3; then compound 1; then compound 2.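

Among these compounds, on this aromatic nitrogen the group is not interchangeable in this assay: butyl in place of isopropyl gives a number 18 percentage points lower from compound 1 to compound 3 (beyond the scatter) and so marks the first single-place step. A change confined to this alkyl group, with no ring, donor, acceptor or charge entering or leaving, is thus enough to lower the maximal response beyond the scatter. Nothing measured bears on why the response falls with this change.

One step cannot tell whether chain length or branching matters, and a propyl or pentyl chain at this nitrogen would separate the two. Also open, from the compounds shown here alone, is how a chain ending in an amine or a carboxylic acid would read here.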